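The source may report more compounds than this note shows. Statements on the series, on what has been measured and on what is new or still open speak of the compounds shown alone.

Of the compounds shown here, three share one core and have been measured in a physicochemical assay for acid dissociation. Compound 1 `COc1cccc(CNCCCNc2ccnc3cc(Oc4cccc(N(C)C)c4)ccc23)c1O` gives 9.28. Compound 2 `COc1cccc(CNCCCNc2ccnc3cc(Oc4ccc(C(C)(C)C)cc4)ccc23)c1O` gives 9.28. Compound 3 `COc1cccc(CNCCCNc2ccnc3cc(Cc4cc(C)cc(C)c4)ccc23)c1O` gives 9.47, and the gaps that separate it from compound 1 and from compound 2 both sit within the scatter, so the three numbers cannot be told apart from one another. The steps among them bear this out: no change at the digits printed from compound 1 to compound 2 (within the scatter), a number 0.19 log units higher from compound 1 to compound 3 (within the scatter), and a number 0.19 log units higher from compound 2 to compound 3 (within the scatter). Each of these swaps a group hanging off the far side of the core, well away from the chain that carries the nitrogen atoms, and none of them moves the number beyond the scatter.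

Compound 4 `COc1cccc(CNCCCNc2ccnc3cc(CCc4ccccc4)ccc23)c1O` is not yet measured. Its structure differs from compound 3 in one place: benzyl in place of 3,5-dimethylphenyl on a saturated chain carbon bound to an aromatic carbon. The change again sits on the outer group, at the same side of the core that was varied in the three measured steps, and those steps were all within the scatter. The same outcome is therefore expected here, with a step of a number 0.02 log units lower from compound 3 to compound 4 (within the scatter) that stays within the scatter. For compound 4 the expected value in this assay is 9.45, with a likely range from 9.15 to 9.75.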

Compound 4, acid dissociation constant: 9.47
Beside the measured number, compound 4's estimate is 0.02 log units below it; measured number inside the range.
By their numbers in this assay, from the lowest: compounds 1, 2, 3 and 4 (each within the scatter of the next).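

In this assay, swapping 3,5-dimethylphenyl for benzyl on a saturated chain carbon bound to an aromatic carbon gives no change at the digits printed from compound 3 to compound 4 (within the scatter), so the outer ring can lose both methyl groups with no readable effect on this number. This step reaches further out on the group than the earlier swaps on the aromatic carbon, and phenethyl, whose ring carries no further group, also stays level with the two phenoxy groups (a number 0.19 log units higher from compound 2 to compound 4 (within the scatter); a number 0.19 log units higher from compound 1 to compound 4 (within the scatter)). Across these four compounds, then, the position tolerates all of these carbon-only and phenoxy groups without a change that can be told from the scatter, and nothing shown here offers a reason for that.

As far as these compounds go, all four compounds keep the same chain carrying the nitrogen atoms, so it remains open whether changes closer to that chain would move the number. Every outer group here is also built around a six-membered aromatic ring of carbon only, and a carboxylic acid or a primary amine on that ring, or a longer chain in place of phenethyl, could still read differently.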